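The source may report more compounds than this note shows. Statements on the series, on what has been measured and on what is new or still open speak of the compounds shown alone.

Measured in a functional assay on A2780 cells (Homo sapiens) for inhibition, read by MTT assay, with a stated time of 72 h; a higher number here means a weaker inhibitor of growth, a lower number a stronger inhibitor of growth:
- compound 1 `O=S(=O)(NCCCCNCc1ccc(Br)cc1)c1cc(C(F)(F)F)cc(C(F)(F)F)c1` gives 2100 nM
- compound 2 `O=S(=O)(NCCCNCc1ccc(Cl)c(C(F)(F)F)c1)c1cc(C(F)(F)F)cc(C(F)(F)F)c1` gives 5900 nM

Compound 2 stands with the higher of the two numbers; the gap to compound 1 lies beyond the usual scatter. Compound 3 `O=S(=O)(NCCCNCc1cccc2ccccc12)c1cc(C(F)(F)F)cc(C(F)(F)F)c1` differs from compound 2 by naphthalen-1-yl in place of 4-chloro-3-(trifluoromethyl)phenyl on a saturated chain carbon bound to an amine nitrogen. Within the data shown here, no measured pair shows this change, so nothing here fixes its size or direction; the expected step is a 1.5-fold lower number from compound 2 to compound 3 (0.17 log units; within the scatter), which is not expected to go beyond the scatter in either direction. Compound 3 is accordingly estimated at 4000 nM, with a range from 1500 nM to 12000 nM in this assay.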

Compound 3, concentration for 50% growth inhibition: 3100 nM
Estimate against measurement, compound 3: 1.3-fold (0.11 log units) above, within the range that was stated.
By their numbers in this assay, from the lowest: compounds 1, 3 and 2 (each within the scatter of the next, the first and the last beyond it).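

In this assay, naphthalen-1-yl in place of 4-chloro-3-(trifluoromethyl)phenyl on a saturated chain carbon bound to an amine nitrogen gives a 1.9-fold lower number from compound 2 to compound 3 (0.28 log units; within the scatter). This position therefore accepts two six-membered aromatic rings of carbon only, with no chlorine or fluorine, in place of one substituted ring, and the two compounds cannot be told apart in this assay. No measurement on hand bears on why the two groups read alike.

Still open, from the compounds shown here alone, is whether this tolerance extends to a carboxylic acid or a dimethylamino group on the aromatic ring. Among these compounds, the single step also does not show whether naphthalen-1-yl would read the same on a different chain.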